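Sulfanyl aryl exchange on a diamino core

The source may hold more compounds than are shown below. What is called first, only, known or untested is meant among the compounds shown, and "the series" means these compounds.

Measured compounds:
Compound 1: `Nc1cc(N)c2nc(-c3ccccc3)c(NCc3ccc(Cl)c(Cl)c3)nc2c1` gives 27500 nM
Compound 2: `Nc1cc(N)c2nc(-c3ccccc3)c(Sc3ccc(F)cc3)nc2c1` gives 30900 nM
Compound 3: `COc1cc(CNc2nc3cc(N)cc(N)c3nc2-c2ccccc2)cc(OC)c1OC` gives 33100 nM

The three compounds share one core and differ in the group attached to it. In a functional assay on A549 cells (Homo sapiens) for inhibition, read by sulforhodamine B assay, with a stated time of 48 h (on this read-out lower numbers stand for stronger inhibition of growth and higher numbers for weaker inhibition of growth), compound 2 gives 30900 nM, the second highest of the three numbers. Its nearest neighbour is compound 3, whose value lies within the usual scatter of that of compound 2, and the furthest is compound 1, whose value also lies within the scatter. On these numbers compound 2 is therefore neither separated from compound 1 nor from compound 3.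

Compound 4, `Nc1cc(N)c2nc(-c3ccccc3)c(Sc3ccc(Cl)c(Cl)c3)nc2c1`, has not yet been measured in this assay. It is reached from compound 2 by a single change: 3,4-dichlorophenyl in place of 4-fluorophenyl on a sulfur.

Among the measured compounds shown here, no step between two measured compounds that differ in one place is available, so the size of this step cannot be read off from the data. Compound 1 carries a 3,4-dichlorophenyl group on a different linker and gives 27500 nM, a number within the scatter of compound 2, which gives 30900 nM. The expected step of a 1.2-fold lower number from compound 2 to compound 4 (0.09 log units; within the scatter) is therefore small, toward a slightly lower number if anything, and not clearly beyond the scatter. Compound 4 is expected to give about 25000 nM, in the range from 10000 nM to 60000 nM.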

Compound 4, concentration for total growth inhibition: 52500 nM
Compound 4: middle estimate off by 2.1-fold (0.32 log units), on the low side, within the range that was stated.
By their numbers in this assay, from the lowest: compounds 1, 2, 3 and 4 (each within the scatter of the next).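

Among the compounds shown here, the exchange of 4-fluorophenyl for 3,4-dichlorophenyl on a sulfur provides the first step in this set that can be read between two compounds differing in one place: in this assay it is a 1.7-fold higher number from compound 2 to compound 4 (0.23 log units; within the scatter). This shows that, for this one exchange at this position, the read-out does not separate compound 4 from compound 2, even though the entering group has two chlorine atoms where the leaving group has one fluorine atom and both groups keep the same six-membered aromatic ring of carbon only. Nothing measured here ties the step to any property of either group.

The compounds shown leave open how this position on the sulfur responds to a group of a different kind, such as an amine, a carboxylic acid or a longer alkyl chain in place of the halogenated phenyl ring. They also leave open whether the sulfur itself can be exchanged for an oxygen atom with the 4-fluorophenyl group kept, and whether any such change would give a step beyond the scatter.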